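Methyl for methoxy on the aryl sulfonyl group

A few compounds are considered here, and "the series" means these few. Any claim that something is new, unique, unknown or untested is made for them only; others in the source may bear on it.

Two compounds of the series carry numbers. In a functional assay on MKN-45 cells (Homo sapiens) for cytotoxicity, read by MTT assay, with a stated time of 72 h (on this read-out higher numbers stand for weaker inhibition and lower numbers for stronger inhibition), compound 1 `COc1cc2c(Oc3ccc(NC(=O)c4cn(-c5ccc(Cl)cc5)cn4)cc3F)ccnc2cc1OCCCN1CCN(C)CC1` gives 4110 nM. Compound 2 `COc1ccc(S(=O)(=O)/C=C/C(=O)Nc2ccc(Oc3ccnc4cc(OCCCN5CCN(C)CC5)c(OC)cc34)c(F)c2)cc1` in this assay gives 2770 nM, the lowest number shown, though compound 1 sits within the scatter of it, so no order between the two is claimed. Compound 3 `COc1cc2c(Oc3ccc(NC(=O)/C=C/S(=O)(=O)c4ccc(C)cc4)cc3F)ccnc2cc1OCCCN1CCN(C)CC1` is derived from compound 2 by methyl in place of methoxy on an aromatic carbon. Among the measured compounds shown here, no measured pair tracks this change, so the step of a 1.0-fold lower number from compound 2 to compound 3 (0.01 log units; within the scatter) is expected to be none beyond the scatter. Compound 3 is therefore estimated at 2700 nM, with a range from 1100 nM to 6500 nM.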

Compound 3, half-maximal inhibitory concentration: 2510 nM
For compound 3 the middle estimate is 1.1-fold (0.03 log units) above the measured one; measured number inside the range.
By their numbers in this assay, from the lowest: compounds 3, 2 and 1 (each within the scatter of the next).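

Among the compounds shown here, replacing 4-methoxyphenyl with 4-methylphenyl on the sulfonyl group in this assay gives a 1.1-fold lower number from compound 2 to compound 3 (0.04 log units; within the scatter), so the first measured pair at this position shows no difference between methoxy and methyl. Changing the group on the carbonyl carbon, with 2-((4-methylphenyl)sulfonyl)ethenyl in place of 1-(4-chlorophenyl)-1H-imidazol-4-yl, gives a 1.6-fold lower number from compound 1 to compound 3 (0.21 log units; within the scatter), so these two groups are not separated either. No measurement offered here bears on the reason for either step.

On these data alone, whether any group on this aromatic carbon can move the number beyond the scatter remains open. An amine or a carboxylic acid there would test this.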